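Exchanging a Five-Membered Ring and the Expected Exposure

A few compounds are considered here, and "the series" means these few. Any claim that something is new, unique, unknown or untested is made for them only; others in the source may bear on it.

Of the compounds shown here, three have been measured in an ADME assay on the whole organism (Mus musculus, strain BALB/c), read by LC-MS, with a stated time of 24 h, at a dose of 1 mg/kg by the intravenous route; a lower number here means less compound in the circulation, a higher number more compound in the circulation at the dose given. Compound 1 `Cn1nccc1-c1cc(C(F)(F)F)ccc1[C@H]1CCc2cc(S(=O)(=O)Nc3ncccn3)ccc21` gives 4250 ng.h/mL, compound 3 `Cn1nccc1-c1cc(C(F)(F)F)ccc1[C@H]1CCOc2cc(S(=O)(=O)Nc3ncccn3)ccc21` gives 6190 ng.h/mL, and compound 2 `Cn1nccc1-c1cc(C(F)(F)F)ccc1[C@H]1CCOc2cc(S(=O)(=O)Nc3nccs3)ccc21` gives 1150 ng.h/mL, the lowest of the three numbers, with compound 1 nearest to it and compound 3 furthest, both beyond the scatter. Going by the values given here, the single measured step, a 5.4-fold higher number from compound 2 to compound 3 (0.73 log units; beyond the scatter), changed only the group on the sulfonamide nitrogen. Compound 4 `O=S(=O)(Nc1nccs1)c1ccc2c(c1)OCC[C@@H]2c1ccc(C(F)(F)F)cc1-n1ccnn1` differs from compound 2 at a different place: 1H-1,2,3-triazol-1-yl in place of 1-methyl-1H-pyrazol-5-yl on an aromatic carbon. Among the compounds with values here, no measured pair varies this position, so that step gives no direct guide, and a change within the scatter is expected, no change at the digits printed from compound 2 to compound 4 (within the scatter). Compound 4 is therefore estimated at 1150 ng.h/mL, with a range from 400 ng.h/mL to 3300 ng.h/mL.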

Compound 4, area under the concentration-time curve: 457 ng.h/mL
Compound 4: the middle estimate sits 2.5-fold (0.40 log units) above what was measured, and the stated range covers the measured number.
By their numbers in this assay, from the lowest: compound 4; then compound 2; then compounds 1 and 3 (each within the scatter of the next).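

Putting 1H-1,2,3-triazol-1-yl in place of 1-methyl-1H-pyrazol-5-yl gives a 2.5-fold lower number from compound 2 to compound 4 (0.40 log units; beyond the scatter) in this assay, so the group on this aromatic carbon also moves the number, not only the group on the sulfonamide nitrogen. This rests on a single pair, and the step is modest. No measurement at hand bears on the reason for it. As far as these compounds go, whether the same exchange lowers the number with pyrimidin-2-yl on the sulfonamide nitrogen stays open. So does how a simpler group here, such as an amine or a nitrile, would read.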